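This account rests on a few compounds, and the source may have more. Where it says the series, first, only, none or still open, it means among the compounds named here.

Working notes on the amide end of the series. In a functional assay on Ishikawa cells (Homo sapiens) for antiproliferative activity, read by CCK-8 assay, with a stated time of 48 h (on this read-out higher numbers stand for weaker inhibition and lower numbers for stronger inhibition), compound 1 (`O=C(/C=C/CNCCOc1ccc(Oc2c(-c3ccc(F)cc3)sc3cc(O)ccc23)cc1)N1CCCC1`) gives 11300 nM, and compound 2 (`CN(C)C(=O)/C=C/CNCCOc1ccc(Oc2c(-c3ccc(F)cc3)sc3cc(O)ccc23)cc1`) gives 11900 nM. Going by the values given here, these are the only two numbers so far, and they lie within the scatter of each other, so compound 2 stands level with compound 1.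

Compound 3 (`O=C(/C=C/CNCCOc1ccc(Oc2c(-c3ccc(F)cc3)sc3cc(O)ccc23)cc1)N1CCCCC1`) has piperidin-1-yl in place of dimethylamino on a carbonyl carbon, keeping the rest of compound 2 unchanged: piperidin-1-yl in place of dimethylamino on a carbonyl carbon. Among the compounds with values here, only one measured step bears on this change, the exchange of pyrrolidin-1-yl and dimethylamino at the same place, and it amounts to a 1.1-fold higher number from compound 1 to compound 2 (0.02 log units; within the scatter). That step lies within the scatter, although it is a single comparison, and no six-membered non-aromatic ring has yet been measured on this carbonyl carbon. On this evidence, no step beyond the scatter is expected in this assay, and no direction can be argued with any confidence. The estimated step is a 1.1-fold lower number from compound 2 to compound 3 (0.05 log units; within the scatter). The estimate for compound 3 is 10500 nM, with an expected range from 6000 nM to 18000 nM.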

Compound 3, half-maximal inhibitory concentration: 8430 nM
Compound 3: middle estimate off by 1.2-fold (0.10 log units), on the high side; the range from low to high includes it.
By their numbers in this assay, from the lowest: compounds 3, 1 and 2 (each within the scatter of the next).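

In this assay, the first six-membered non-aromatic ring on this carbonyl carbon stays level with both earlier amides: the exchange for dimethylamino gives a 1.4-fold lower number from compound 2 to compound 3 (0.15 log units; within the scatter) and the exchange for pyrrolidin-1-yl gives a 1.3-fold lower number from compound 1 to compound 3 (0.13 log units; within the scatter) on the same read-out. With compound 1, compound 2 and compound 3 all within the scatter of one another, neither the presence of a ring nor the size of the ring, across these three groups, separates the compounds, and the added heavy atoms of piperidin-1-yl bring no step beyond the scatter. No measurement at hand offers an explanation for these numbers lying together.

Open, from the compounds shown here alone, is whether a group with a further hetero atom in the ring, such as morpholin-4-yl or 4-methylpiperazin-1-yl, or a secondary amide that keeps the amide hydrogen, would move the number on this carbonyl carbon beyond the scatter. Also open, going by these compounds, is whether any change at this carbonyl carbon matters once the 3-carbamoylprop-2-en-1-yl chain itself gives way to a saturated or longer chain.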